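This account rests on a few compounds, and the source may have more. Where it says the series, first, only, none or still open, it means among the compounds named here.

Compound 1 `CCn1cc(-c2nc3ccccc3[nH]2)c(=O)c2cc(F)c(N3CCNCC3)nc21`: 4800 nM
Compound 2 `CCn1cc(-c2nc3ccc(Cl)cc3[nH]2)c(=O)c2cc(F)c(N3CCNCC3)nc21`: 6300 nM

Going by the values given here, in a functional assay on A2780 cells (Homo sapiens) for cytotoxicity, read by MTT assay, with a stated time of 48 h (on this read-out higher numbers stand for weaker inhibition and lower numbers for stronger inhibition), compound 2 gives 6300 nM and sits level with compound 1, as only two numbers exist and they do not separate. The next entry is compound 3 `CCn1cc(-c2nc3ccc([N+](=O)[O-])cc3[nH]2)c(=O)c2cc(F)c(N3CCNCC3)nc21`, which carries nitro in place of chloro on an aromatic carbon. Among the compounds with values here, one measured step bears on this change, at the same carbon: a 1.3-fold higher number from compound 1 to compound 2 (0.12 log units; within the scatter) for chloro in place of hydrogen. Within the data shown here, that step stays within the scatter, but no nitro compound has been measured, so the support is thin. The expected move is a 1.3-fold lower number from compound 2 to compound 3 (0.10 log units; within the scatter) in this estimate, which means no step beyond the scatter and no firm direction in this assay for now. For compound 3 the estimated value is 5000 nM with an expected range of 1800 nM to 12000 nM on this basis.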

Compound 3, half-maximal inhibitory concentration: 12400 nM
The estimate for compound 3 lay 2.5-fold (0.39 log units) below the measured number; measured number above the stated range.
By their numbers in this assay, from the lowest: compounds 1, 2 and 3 (each within the scatter of the next, the first and the last beyond it).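

At this aromatic carbon, this assay now gives a first separation beyond the scatter: nitro in place of hydrogen reads as a 2.6-fold higher number from compound 1 to compound 3 (0.41 log units; beyond the scatter) and marks weaker inhibition, a separation the chloro compound did not provide. Nitro in place of chloro reads as a 2.0-fold higher number from compound 2 to compound 3 (0.29 log units; within the scatter) and stays within the scatter, so compound 2 and compound 3 do not separate, and the series shows only a modest difference between its two ends rather than a clear ranking of the substituents. No supporting measurement bears on why nitro separates from hydrogen at this carbon.

Still open, going by these compounds, is whether an amine, a carboxylic acid or a methoxy group at the same carbon would stay level with compound 1 or follow compound 3. With only chloro and nitro in hand, a substituent trend cannot be drawn from this position.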